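Swapping the amine's naphthyl ring for a fluorophenyl ring

The compounds below may be only part of what the source reports. "The series", "measured", "known", "first", "only" and "open" are said of these compounds alone.

Compound 1 `C=C1[C@@H](OC(C)=O)C[C@@H]2[C@](C)(COC=O)[C@H](OC(C)=O)CC[C@@]2(C)[C@@H]1C[C@@H](Nc1cccc2ccccc12)C1=CCOC1=O` and compound 2 `C=C1[C@@H](OC(C)=O)C[C@@H]2[C@](C)(CO[Si](C)(C)C(C)(C)C)[C@H](OC(C)=O)CC[C@@]2(C)[C@@H]1C[C@@H](Nc1cccc2ccccc12)C1=CCOC1=O` share one core and differ only at an oxygen on a saturated carbon, where a 1.7-fold higher number from compound 1 to compound 2 (0.24 log units; within the scatter). In a functional assay on HT-29 cells (Homo sapiens) for cytotoxicity, read by sulforhodamine B assay (a higher number here means a weaker inhibitor, a lower number a stronger inhibitor), compound 1 gives 8670 nM, the lower of the two numbers, while compound 2 gives 15000 nM. Compound 3 `C=C1[C@@H](OC(C)=O)C[C@@H]2[C@](C)(COC=O)[C@H](OC(C)=O)CC[C@@]2(C)[C@@H]1C[C@@H](Nc1ccc(F)cc1)C1=CCOC1=O` keeps the smaller oxygen group of compound 1 and changes a different place: 4-fluorophenyl in place of naphthalen-1-yl on an amine nitrogen. For the measured compounds named here, the only measured step, from compound 1 to compound 2, touches another part of the molecule and so says nothing about this change; no measured pair here varies the group on the amine nitrogen. For compound 3 the expected value in this assay is therefore centred near compound 1, at 10000 nM with a wide range from 3000 nM to 40000 nM. That estimate amounts to a step of a 1.2-fold higher number from compound 1 to compound 3 (0.06 log units; within the scatter), which is not expected to stand out beyond the scatter.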

Compound 3, half-maximal inhibitory concentration: 20500 nM
The estimate for compound 3 lay 2.1-fold (0.31 log units) below the measured number; measured number inside the range.
By their numbers in this assay, from the lowest: compounds 1, 2 and 3 (each within the scatter of the next, the first and the last beyond it).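

The group on the amine nitrogen does register in this assay: 4-fluorophenyl in place of naphthalen-1-yl gives a 2.4-fold higher number from compound 1 to compound 3 (0.37 log units; beyond the scatter), so of these two groups naphthalen-1-yl goes with the stronger inhibitor, though only modestly. For the compounds shown here, the earlier step at the oxygen on a saturated carbon, a 1.7-fold higher number from compound 1 to compound 2 (0.24 log units; within the scatter), did not stand out in this way, so this is the first change here that moves the number beyond the scatter. Nothing measured here explains the shift.

The swap removes an aromatic ring and adds a fluorine in a single step, so the two changes cannot be told apart here. Plain phenyl would help separate them, while naphthalen-2-yl or cyclohexyl on the same nitrogen would show whether the shape of the ring system matters at this position.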